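This account rests on a few compounds, and the source may have more. Where it says the series, first, only, none or still open, it means among the compounds named here.

The measured compounds in a functional assay on PC-3 cells (Homo sapiens) for cytotoxicity, read by sulforhodamine B assay; on this read-out lower numbers stand for higher toxicity in this test and higher numbers for lower toxicity in this test:

compound 1, `COc1cccc(OC)c1OCCNCCOc1ccccc1OCc1ccccc1`: 193000 nM
compound 2, `COc1cccc(OC)c1OCCNCCOc1ccccc1OCc1ccc(C)cc1`: 61700 nM
compound 3, `COc1ccccc1COc1ccccc1OCCNCCOc1c(OC)cccc1OC`: 100000 nM

Compound 3 stands second highest of the three numbers in this assay. Its nearest neighbour is compound 2, reached by a 1.6-fold higher number from compound 2 to compound 3 (0.21 log units; within the scatter), and its furthest is compound 1, from which a 1.9-fold lower number from compound 1 to compound 3 (0.29 log units; within the scatter) leads to it; both of these gaps lie within the scatter. For the measured compounds named here, only the step of a 3.1-fold lower number from compound 1 to compound 2 (0.50 log units; beyond the scatter) is beyond the scatter.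

Compound 4, `COc1cccc(COc2ccccc2OCCNCCOc2c(OC)cccc2OC)c1`, is not yet measured. It differs from compound 3 in one place: 3-methoxyphenyl in place of 2-methoxyphenyl on a saturated chain carbon bound to an oxygen on an aromatic ring.

Going by the values given here, no measured step exchanges one methoxyphenyl for another, so none bears directly on this change. The two steps that alter the same part of the molecule, a 1.9-fold lower number from compound 1 to compound 3 (0.29 log units; within the scatter) and a 1.6-fold higher number from compound 2 to compound 3 (0.21 log units; within the scatter), were both within the scatter, so this position has so far tolerated changes without a clear effect. A step in this assay that stays within the scatter is therefore expected, in no particular direction.

Compound 4 is accordingly estimated at 90000 nM in this assay, with a range from 40000 nM to 200000 nM, the expected step being a 1.1-fold lower number from compound 3 to compound 4 (0.05 log units; within the scatter).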

Compound 4, concentration lethal to 50% of the cells: 61700 nM
Estimate against measurement, compound 4: 1.5-fold (0.16 log units) above, and the stated range covers the measured number.
By their numbers in this assay, from the lowest: compounds 2, 4, 3 and 1 (each within the scatter of the next, the first and the last beyond it).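

In this assay, for the compounds shown here, the exchange of 2-methoxyphenyl for 3-methoxyphenyl is the first direct swap of one methoxyphenyl for another, and a 1.6-fold lower number from compound 3 to compound 4 (0.21 log units; within the scatter) shows no clear effect of this change on its own. Adding a methoxy group now gives a 3.1-fold lower number from compound 1 to compound 4 (0.50 log units; beyond the scatter) and thus a modest step beyond the scatter, whereas a 1.9-fold lower number from compound 1 to compound 3 (0.29 log units; within the scatter) stayed within it, although the gap between compound 3 and compound 4 is too small to separate the two methoxyphenyl groups. Compound 4 also cannot be told apart from compound 2, with no change at the digits printed from compound 2 to compound 4 (within the scatter) for the exchange of 4-methylphenyl for 3-methoxyphenyl, and nothing shown here explains any of these steps.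

Still open, on these data alone, is whether 4-methoxyphenyl at this place would also stay within the scatter of compound 3 and compound 4. As far as these compounds go, it is equally open whether a more different group on this ring, such as a carboxylic acid or an amine, would move the number further than any methoxy or methyl has so far.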